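This account rests on a few compounds, and the source may have more. Where it says the series, first, only, none or still open, it means among the compounds named here.

Measured so far in a functional assay on MCF7 cells (Homo sapiens) for inhibition, read by trypan blue exclusion, with a stated time of 3 days; a lower number here means a stronger inhibitor, a higher number a weaker inhibitor
compound 1 `COc1cc(C(=O)c2cn(-c3ccccc3)cc2-c2cccc(C)c2)cc(OC)c1OC` gives 450 nM
compound 2 `COc1cc(C(=O)c2cn(-c3ccccc3)cc2-c2cccc(N)c2)cc(OC)c1OC` gives 28 nM
compound 3 `COc1cc(C(=O)c2cn(-c3ccccc3F)cc2-c2ccccc2)cc(OC)c1OC` gives 85 nM

Of these three numbers, compound 3 at 85 nM is the middle one, higher than compound 2 and lower than compound 1, with both gaps beyond the scatter. Compound 4 `COc1cc(C(=O)c2cn(-c3cccc(F)c3)cc2-c2ccccc2)cc(OC)c1OC` differs from compound 3 by 3-fluorophenyl in place of 2-fluorophenyl on an aromatic nitrogen with 3-fluorophenyl in place of 2-fluorophenyl on an aromatic nitrogen. For the measured compounds named here, the only measured step, a 16-fold lower number from compound 1 to compound 2 (1.21 log units; beyond the scatter) for amino in place of methyl on an aromatic carbon, is large but is a different change, so it sets no size here. No direction can be expected in this assay and no step beyond the scatter is expected. The expected outcome is a 1.2-fold higher number from compound 3 to compound 4 (0.07 log units; within the scatter) as a working estimate. For compound 4 the estimate is 100 nM with 35 nM to 300 nM as the expected range.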

Compound 4, half-maximal inhibitory concentration: 350 nM
For compound 4 the middle estimate is 3.5-fold (0.54 log units) below the measured one; the measured number lies above the stated range.
By their numbers in this assay, from the lowest: compound 2; then compound 3; then compounds 4 and 1 (each within the scatter of the next).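

In this assay, 3-fluorophenyl in place of 2-fluorophenyl on the aromatic nitrogen gives a 4.1-fold higher number from compound 3 to compound 4 (0.61 log units; beyond the scatter) and a step beyond the scatter. For the compounds shown here, this is the first reading on this position, and it shows that the number responds to where the fluorine sits on that phenyl ring, even though the two compounds have the same atoms. Nothing available gives a reason for this step. Still open, from the compounds shown here alone, are how 4-fluorophenyl or 2-chlorophenyl would read at this nitrogen, and whether 2-fluorophenyl and the amino group of compound 2 would combine in one compound.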